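From hydroxy to methoxy: an estimate for compound 3

The compounds below may be only part of what the source reports. "The series", "measured", "known", "first", "only" and "open" are said of these compounds alone.

In a functional assay on B16 cells (Mus musculus) for inhibition (a higher number here means a weaker inhibitor, a lower number a stronger inhibitor), compound 1 (`CCc1ccc(NC(N)=S)cc1`) gives 4900 nM as its half-maximal inhibitory concentration, and compound 2 (`NC(=S)Nc1ccc(O)cc1`) gives 6300 nM on the same read-out. Compound 2 therefore holds no separate rank, as the two values lie within the scatter of each other.

Compound 3 (`COc1ccc(NC(N)=S)cc1`) has not yet been measured. It differs from compound 2 by methyl in place of hydrogen on an oxygen on an aromatic ring, which turns hydroxy to methoxy (methyl in place of hydrogen on an oxygen on an aromatic ring).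

Among the measured compounds shown here, only one measured step bears on this change, and only indirectly. Hydroxy in place of ethyl on an aromatic carbon amounts to a 1.3-fold higher number from compound 1 to compound 2 (0.11 log units; within the scatter) in this assay and stays small. For the measured compounds named here, no measured compound yet shows what a methoxy group does here, so the expectation remains loose, and no step beyond the scatter is anticipated. The expected change is a 1.1-fold lower number from compound 2 to compound 3 (0.06 log units; within the scatter) and no more than that. Compound 3 is estimated at 5500 nM in this assay with an expected range from 2500 nM to 12000 nM as the likely span.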

Compound 3, half-maximal inhibitory concentration: 5600 nM
Beside the measured number, compound 3's estimate is 1.0-fold (0.01 log units) below it; measured number inside the range.
By their numbers in this assay, from the lowest: compounds 1, 3 and 2 (each within the scatter of the next).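

In this assay, methyl in place of hydrogen on an oxygen on an aromatic ring gives a 1.1-fold lower number from compound 2 to compound 3 (0.05 log units; within the scatter), so this change adds a carbon without a step that stands out from the scatter. Exchanging the ethyl group for methoxy gives a 1.1-fold higher number from compound 1 to compound 3 (0.06 log units; within the scatter), which extends the picture from two groups to three: ethyl, hydroxy and methoxy at this place all give numbers that cannot be told apart, and no order can be drawn among compounds 1, 2 and 3. Nothing measured here offers an explanation for this lack of separation.

The compounds shown do not tell whether any group at this place can move the number beyond the scatter, as they leave open what an amine, a carboxylic acid, a chlorine atom or a longer chain such as propoxy would do. They also leave open how much of the level of these numbers belongs to the shared core and how much to the group it carries.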